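Propoxy for tert-butyl on a trimethoxy stilbene series

The source may hold more compounds than are shown below. What is called first, only, known or untested is meant among the compounds shown, and "the series" means these compounds.

The three measured compounds share a trimethoxyphenyl core. Compound 1 `COC(=O)C(Cc1cc(OC)c(OC)c(OC)c1)c1ccc(OC)cc1` gives only a limit of > 25 uM in a functional assay on MLM cells (Homo sapiens) for cytotoxicity, using microsomes (a higher number here means that more compound is needed for the effect, a lower number that less compound is needed), not a number. Compound 2 `COc1cc(/C=C/c2ccc(C(C)(C)C)cc2)cc(OC)c1OC` likewise gives only a limit of > 25 uM in this assay. Compound 3 `COc1cc(/C=C\c2ccc(SC)cc2)cc(OC)c1OC`, in this assay, gives a measured value of 3.3 uM. So compound 2 stands at the limit of > 25 uM in this assay, at which 2 of the 3 values shown sit, with no number of its own to compare against compound 3, and no step between measured compounds is known.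

Compound 4 `CCCOc1ccc(/C=C/c2cc(OC)c(OC)c(OC)c2)cc1` differs from compound 2 by propoxy in place of tert-butyl on an aromatic carbon. Going by the values given here, no measured pair shows what this exchange does in this assay. The step that the limit leaves unreadable from compound 2 to compound 4 is expected to be small, with no direction beyond the scatter, because compound 2 itself sits at the limit of > 25 uM in this assay, at which 2 of the 3 values shown sit, and most likely compound 4 will return a limit as well. Compound 4 is expected at 30 uM, with a range from 8 uM to 100 uM.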

Compound 4, concentration for half-maximal effect: > 25 uM
Compound 4 ended at the assay's limit (the forecaster's own chance of this, stated with the estimate: 65%); the middle value is on the limit's open side.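

Compound 2 and compound 4 both end at a limit in this assay, so no step can be read between them: the limit of > 25 uM in this assay, at which 3 of the 4 values shown sit.

What propoxy in place of tert-butyl does in this assay stays open, and compound 3 remains the only compound shown with a measured number.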